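The source may report more compounds than this note shows. Statements on the series, on what has been measured and on what is new or still open speak of the compounds shown alone.

The series shares one core; compound 1 is `c1cnc2c(c1)CN[C@@H](CN(CCCCNC1CCOCC1)[C@H]1CCCc3cccnc31)C2` and compound 2 is `c1cnc2c(c1)CN[C@@H](CN(CCCCNC1COC1)[C@H]1CCCc3cccnc31)C2`. In an assay on isolated protein for inhibition of Alpha-2C adrenergic receptor (Homo sapiens) (on this read-out lower numbers stand for stronger inhibition and higher numbers for weaker inhibition), compound 1 reaches only the assay limit, > 30000 nM. In this assay compound 2 gives 8800 nM, the only number shown so far. Among the measured compounds shown here, the step of an at least 3.4-fold lower number from compound 1 to compound 2 (0.53 log units; beyond the scatter) is the sole measured change, and its size is bounded by the limit of > 30000 nM in this assay, at which 1 of the 2 values shown sits. Compound 3 is `c1cnc2c(c1)CN[C@@H](CN(CCCC1CCNCC1)[C@H]1CCCc3cccnc31)C2`; it differs from compound 2 by piperidin-4-yl in place of ((oxetan-3-yl)amino)methyl on a saturated chain carbon, three bonds along the chain from an amine nitrogen. For the measured compounds named here, no measured step covers this exchange; the one available step concerns a different ring swap on the amine nitrogen and bears only loosely on it. On that basis a step of modest size at most is expected, a 1.5-fold lower number from compound 2 to compound 3 (0.17 log units; within the scatter), with the direction uncertain. For compound 3 the expected value in this assay is 6000 nM, within a range from 1500 nM to 25000 nM.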

Compound 3, half-maximal inhibitory concentration: 2200 nM
Estimate against measurement, compound 3: 2.7-fold (0.44 log units) above; the measured number falls inside the stated range.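

In this assay, the exchange on a saturated chain carbon, three bonds along the chain from an amine nitrogen, gives a 4.0-fold lower number from compound 2 to compound 3 (0.60 log units; beyond the scatter), so this position also moves the number, and compound 3 at 2200 nM is the most potent of the three. Against the oxan-4-yl compound the same change reads an at least 13-fold lower number from compound 1 to compound 3 (1.13 log units; beyond the scatter), a larger step than the ring swap on the amine nitrogen alone gave. Compound 1 stands at an assay limit, so this step has a bound and no exact size: the limit of > 30000 nM in this assay, at which 1 of the 3 values shown sits.

The exchange alters the ring and the place of the nitrogen together, and the compounds shown do not separate these two changes. On these data alone, whether a piperidin-3-yl group, a 1-methylpiperidin-4-yl group or a longer chain carrying the piperidine would lower the number further stays open.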